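Shortening a Long Chain on a Receptor Ligand

A few compounds are considered here, and "the series" means these few. Any claim that something is new, unique, unknown or untested is made for them only; others in the source may bear on it.

Compound 1 `CCCCCCCCCCCCc1ccccc1C(SCCC(=O)O)SCCC(=O)O` bears a long saturated chain on its aromatic core. In an assay on membranes from lung (Cavia porcellus) for binding affinity to cysteinyl leukotriene receptor (Homo sapiens) (on this read-out lower numbers stand for stronger inhibition and higher numbers for weaker inhibition), compound 1 gives 445 nM. Compound 2 `CCCCCCCCCCc1ccccc1C(SCCC(=O)O)SCCC(=O)O` differs from compound 1 by hydrogen in place of ethyl on a saturated chain carbon, ten or more bonds along the chain from an aromatic carbon, and in this assay compound 2 gives 1180 nM. That change made a 2.7-fold higher number from compound 1 to compound 2 (0.42 log units; beyond the scatter).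

Compound 3 `CCCCCCCCCCCOc1cccc(C(SCCC(=O)O)SCCC(=O)O)c1` is built on a different core; the difference between the core of compound 1 and the core of compound 3 is not broken down here. In this assay, for the measured compounds named here, compound 3 gives 78 nM, the lowest of the three numbers measured so far.

Compound 4 `CCCCCCCCCOc1cccc(C(SCCC(=O)O)SCCC(=O)O)c1` has not yet been measured. It differs from compound 3 by hydrogen in place of ethyl on a saturated chain carbon, nine bonds along the chain from an oxygen on an aromatic ring. Going by the values given here, this is the same kind of change as the one from compound 1 to compound 2, though the place of the change is not the same. In this assay, among the compounds with values here, the expected step is a 2.7-fold higher number from compound 3 to compound 4 (0.43 log units; beyond the scatter), set beside the earlier one, because a 2.7-fold higher number from compound 1 to compound 2 (0.42 log units; beyond the scatter) is the only measured example of this shortening. Whether a different core carries the step over unchanged cannot be known from these compounds alone, so the range is kept wide. Compound 4 is therefore estimated to give about 210 nM, between 100 nM and 450 nM.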

Compound 4, inhibition constant: 624 nM
For compound 4 the middle estimate is 3.0-fold (0.47 log units) below the measured one; measured number outside the range, above it.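

In this assay, the shortening gives an 8.0-fold higher number from compound 3 to compound 4 (0.90 log units; beyond the scatter), so the number rises on both cores, but the size of the rise does not carry over from one core to the other: the same change on two cores in this assay, a 2.7-fold higher number (0.42 log units; beyond the scatter) from compound 1 to compound 2 and an 8.0-fold higher number (0.90 log units; beyond the scatter) from compound 3 to compound 4, 3.0-fold (0.48 log units) apart, beyond the scatter of two such steps

Within these four compounds, then, the direction of the change is shared, and a step read on one core gives only a rough guide to the step on another. This rests on just two pairs, and the change does not sit at the same place in both, so the compounds cannot show why the two steps differ or which of the two sizes a further core would follow.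

The compounds shown leave open what a longer chain would do on the core of compound 3, and whether the number would keep falling as the chain grows or would turn back at some length. They also leave open whether an amine in place of the oxygen that joins the chain to the aromatic ring would keep the number of compound 3 or move it.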